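The source may report more compounds than this note shows. Statements on the series, on what has been measured and on what is new or still open speak of the compounds shown alone.

Working notes on the series. Three measured compounds share one core and differ only in the group on the aromatic nitrogen. Compound 1 `Cc1ccccc1-n1nncc1CN1C(=O)C2(C(C#N)=C(N)Oc3c(N)cc4nc5ccccc5nc4c32)c2ccccc21` carries a 2-methylphenyl there. In a functional assay on HepG2 cells (Homo sapiens) for antiproliferative activity, read by MTT assay, with a stated time of 48 h (on this read-out lower numbers stand for stronger inhibition and higher numbers for weaker inhibition), compound 1 reports only the limit > 50000 nM. Compound 2 `N#CC1=C(N)Oc2c(N)cc3nc4ccccc4nc3c2C12C(=O)N(Cc1cnnn1-c1ccccc1Cl)c1ccccc12` carries a 2-chlorophenyl. In this assay compound 2 gives 33500 nM. Compound 3 `N#CC1=C(N)Oc2c(N)cc3nc4ccccc4nc3c2C12C(=O)N(Cc1cnnn1-c1ccc([N+](=O)[O-])cc1)c1ccccc12` carries a 4-nitrophenyl. In this assay compound 3 reports only the limit > 50000 nM. The steps are an at least 1.4-fold lower number from compound 1 to compound 2 (0.17 log units; that floor lies within the scatter), an at least 1.4-fold higher number from compound 2 to compound 3 (0.17 log units; that floor lies within the scatter) and a step that the two limits leave unreadable from compound 1 to compound 3. Compound 3 thus stands at the limit (the limit of > 50000 nM in this assay, at which 2 of the 3 values shown sit), and no number is known for it.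

Compound 4 `N#CC1=C(N)Oc2c(N)cc3nc4ccccc4nc3c2C12C(=O)N(Cc1cnnn1-c1ccc([N+](=O)[O-])cc1[N+](=O)[O-])c1ccccc12` differs from compound 3 by one change, (nitro in place of hydrogen on an aromatic carbon), on an aromatic carbon of a six-membered aromatic ring of carbon only. Within the data shown here, only one measured step involves a nitro group, an at least 1.4-fold higher number from compound 2 to compound 3 (0.17 log units; that floor lies within the scatter), which reached the limit; the step that the two limits leave unreadable from compound 1 to compound 3 is unreadable between two limits. Among the measured compounds shown here, no measured step shows a second nitro on the same ring. For the measured compounds named here, with compound 3 already at the limit and the one relevant step pointing toward higher numbers, no readable step beyond the scatter is expected, and the estimated step is a step that the limit leaves unreadable from compound 3 to compound 4. Compound 4 is expected to report 70000 nM in this assay, between 30000 nM and 200000 nM, most likely again as a limit.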

Compound 4, half-maximal inhibitory concentration: 18400 nM
Estimate against measurement, compound 4: 3.8-fold (0.58 log units) above; the measured number lies below the stated range.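

Among these compounds, on this ring, a nitro group ortho to a large group and meta to a nitro group gives the first readable step beyond the scatter in this assay: an at least 2.7-fold lower number from compound 3 to compound 4 (0.43 log units; beyond the scatter). Among the compounds shown here, this shows that a second nitro group does not leave the compound at the limit, as the single nitro group of compound 3 did, and the 2,4-dinitrophenyl group also stands clear of the 2-methylphenyl group, with an at least 2.7-fold lower number from compound 1 to compound 4 (0.43 log units; beyond the scatter), while a 1.8-fold lower number from compound 2 to compound 4 (0.26 log units; within the scatter) leaves it not separable from the 2-chlorophenyl group. The two steps beyond the scatter are floors only, and their true size stays unknown: the limit of > 50000 nM in this assay, at which 2 of the 4 values shown sit.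

The compounds shown leave open whether a nitro group in this place works alone or needs the nitro group already on the ring, which a 2-nitrophenyl group would separate. They also leave open whether an amine or a carboxylic acid in the same place would move the number in the same direction, and whether any group on this ring can reach well below the values of compound 2 and compound 4.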